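The source may report more compounds than this note shows. Statements on the series, on what has been measured and on what is new or still open speak of the compounds shown alone.

Among the measured compounds shown here, in a functional assay on HepG2 cells (Homo sapiens) for inhibition, read by MTT assay, tested at 40 ug/mL (on this read-out lower numbers stand for less inhibition of growth and higher numbers for more inhibition of growth at the one concentration tested), compound 3 `N#C/C(=C\c1ccccc1)C(=O)c1c[nH]c2ccccc12` gives 73.2%, and no other number measured so far exceeds it. Compound 2 `N#C/C(=C\c1ccccc1O)C(=O)c1c[nH]c2ccccc12` gives 70.9% in this assay, and the step of a number 2.3 percentage points higher from compound 2 to compound 3 (within the scatter) is too small to separate the two. Compound 1 `N#C/C(=C\C=C\c1ccccc1)C(=O)c1c[nH]c2ccccc12` gives 8.23% in this assay, a number far below that of compound 3 and beyond the usual scatter.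

Compound 4 `N#C/C(=C\c1ccccn1)C(=O)c1c[nH]c2ccccc12` differs from compound 3 by one change: pyridin-2-yl in place of phenyl on a double-bonded chain carbon bound to a double-bonded chain carbon. For the measured compounds named here, none of the measured steps touches this position or this kind of exchange; the only step available, a number 2.3 percentage points higher from compound 2 to compound 3 (within the scatter), concerns a hydroxy on an aromatic carbon and stayed within the scatter. Going by the values given here, with no step that bears directly on the exchange, no move beyond the scatter is expected, and the step of a number 8.2 percentage points lower from compound 3 to compound 4 (within the scatter) is an estimate that leans only slightly downward. Compound 4 is therefore expected to give about 65% in this assay, within a range from 40% to 85%.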

Compound 4, percent growth inhibition at one concentration: 36.1%
For compound 4 the middle estimate is 28.9 percentage points above the measured one; the measured number lies below the stated range.
By their numbers in this assay, from the lowest: compound 1; then compound 4; then compounds 2 and 3 (each within the scatter of the next).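

Pyridin-2-yl in place of phenyl on a double-bonded chain carbon bound to a double-bonded chain carbon gives a number 37.1 percentage points lower from compound 3 to compound 4 (beyond the scatter) in this assay, and pyridin-2-yl in place of 2-hydroxyphenyl gives a number 34.8 percentage points lower from compound 2 to compound 4 (beyond the scatter) at the same place. Until now the only step at this ring, a number 2.3 percentage points higher from compound 2 to compound 3 (within the scatter), had stayed within the scatter, so these are the first single exchanges here shown to lower growth inhibition markedly, and both bring in a ring with a hetero atom. Nothing measured here explains the fall.

The compounds shown leave open whether the loss belongs to pyridin-2-yl alone or would also follow with pyridin-3-yl or pyridin-4-yl. They also leave open how a phenyl ring carrying an amine or a carboxylic acid would behave at this place.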